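A few compounds are considered here, and "the series" means these few. Any claim that something is new, unique, unknown or untested is made for them only; others in the source may bear on it.

The measured compounds are compound 1 `CCCNC(=O)COc1ccc2cc(C(O)(C(F)(F)F)C(F)(F)F)c(O)cc2c1` and compound 2 `O=C(COc1ccc2cc(C(O)(C(F)(F)F)C(F)(F)F)c(O)cc2c1)NCc1ccccc1`. In an assay on isolated protein for inhibition of tyrosine-protein phosphatase non-receptor type 13 (Homo sapiens), read by spectrophotometry (a higher number here means a weaker inhibitor, a lower number a stronger inhibitor), compound 1 gives > 20000 nM, which is a limit of the assay rather than a number. In this assay compound 2 gives > 20000 nM, again a limit of the assay and not a number. Compound 2 thus stands at the limit of > 20000 nM in this assay, at which 2 of the 2 values shown sit, together with compound 1. Going by the values given here, the only measured step, a step that the two limits leave unreadable from compound 1 to compound 2, cannot be read, since both of its ends are limits.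

Compound 3 `CC(C)c1ccc(NC(=O)COc2ccc3cc(C(O)(C(F)(F)F)C(F)(F)F)c(O)cc3c2)cc1` is not yet measured. It differs from compound 2 by 4-isopropylphenyl in place of benzyl on an amide-type nitrogen. Among the compounds with values here, the one measured step bears on this change only loosely: it shows that exchanging ethyl for phenyl on the chain carbon bound to the amide-type nitrogen did not bring the value below the limit, and nothing more. No direction or size can be read from it. Compound 3 is therefore expected to remain at the limit as well, and its value in this assay is estimated at 30000 nM, in the range 10000 nM to 100000 nM. The step that the limit leaves unreadable from compound 2 to compound 3 is expected to be nothing beyond the scatter.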

Compound 3, half-maximal inhibitory concentration: 6500 nM
The estimate for compound 3 lay 4.6-fold (0.66 log units) above the measured number; the whole stated range lies above it.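

In this assay, putting 4-isopropylphenyl in place of benzyl on the amide-type nitrogen gives an at least 3.0-fold lower number from compound 2 to compound 3 (0.48 log units; beyond the scatter), and putting it in place of propyl gives an at least 3.0-fold lower number from compound 1 to compound 3 (0.48 log units; beyond the scatter). Going by these compounds alone, compound 1 and compound 2 each give a limit of the assay rather than a number, so these two steps give only the smallest possible size of the change, and the step between those two compounds cannot be read: the limit of > 20000 nM in this assay, at which 2 of the 3 values shown sit. Compound 3 is thus the first compound here with a measured number, which shows that the group on this nitrogen can change the read-out, something the two earlier compounds could not show.

The change from benzyl to 4-isopropylphenyl does two things at once, removing the chain carbon between the ring and the nitrogen and adding an isopropyl group, so the compounds shown cannot say which of the two matters, or whether both do; an unsubstituted phenyl and a 4-isopropylbenzyl group on the same nitrogen would separate them. Also open, going by these compounds, is how other groups at this place would read, such as a carboxylic acid or an amine carried on the ring, or a longer alkyl chain in place of the isopropyl.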